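Sulfide to Sulfoxide on a Side Chain: What to Expect

A few compounds are considered here, and "the series" means these few. Any claim that something is new, unique, unknown or untested is made for them only; others in the source may bear on it.

Compound 1, `Cc1c(CCSCCO)cc(-c2ccc(S(C)(=O)=O)cc2)n1-c1ccccc1`: in an assay on J774 cells for inhibition of prostaglandin G/H synthase 1 (Mus musculus), read by immunoassay, with stated times of 15 min and 30 min (a lower number here means a stronger inhibitor, a higher number a weaker inhibitor), compound 1 gives > 10000 nM, which is a limit of the assay and not a number.
Compound 2, `Cc1c(CCSCCO)cc(-c2ccc(S(C)(=O)=O)cc2)n1-c1ccc(F)c(F)c1`: in this assay compound 2 gives > 10000 nM, likewise a limit.

Going by the values given here, compound 1 therefore stands at the limit, with no number of its own, and the one further value shown sits at the same limit, as the limit of > 10000 nM in this assay, at which 2 of the 2 values shown sit, records. Among the compounds with values here, the only step between measured compounds, a step that the two limits leave unreadable from compound 1 to compound 2, is accordingly unreadable, and it concerns a different part of the molecule in any case.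

Compound 3, `Cc1c(CC[S+]([O-])CCO)cc(-c2ccc(S(C)(=O)=O)cc2)n1-c1ccccc1`, differs from compound 1 by a group of 5 heavy atoms (2 carbon, 2 oxygen, 1 sulfur; no ring) in place of a group of 4 heavy atoms (2 carbon, 1 oxygen, 1 sulfur; no ring), on a saturated chain carbon, two bonds along the chain from an aromatic carbon. Within the data shown here, no measured step touches this side chain, so nothing in the data speaks for a change beyond the scatter in either direction, while both values shown rest at the limit (the limit of > 10000 nM in this assay, at which 2 of the 2 values shown sit). The step from compound 1 to compound 3 is therefore expected to be a step that the limit leaves unreadable from compound 1 to compound 3, most likely again unreadable. Compound 3 is estimated to give 15000 nM in this assay, with a range from 4000 nM to 60000 nM.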

Compound 3, half-maximal inhibitory concentration: > 10000 nM
Compound 3 gave a limit, no number; the forecaster's own chance of this, stated with the estimate: 75%; the middle value lies beyond the limit too.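

Compound 1 and compound 3 both rest at a limit and not at a number, so no step between them can be read, and the same holds for compound 2: the limit of > 10000 nM in this assay, at which 3 of the 3 values shown sit.

The compounds shown leave open what number any of them would give in this assay, and whether the 3,4-difluorophenyl of compound 2 or the altered side chain of compound 3 shifts inhibition at all.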